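Swapping the Sulfonyl Ring From Chlorophenyl to Pyridinyl

This account rests on a few compounds, and the source may have more. Where it says the series, first, only, none or still open, it means among the compounds named here.

Compound 1 `CC(C)(C)c1ccc(CN(Cc2cccc(CCC(=O)O)c2)S(=O)(=O)c2nccs2)cc1` carries a 1,3-thiazol-2-yl group on its sulfonyl sulfur. In an assay on HEK293 cells for inhibition of prostaglandin E2 receptor EP2 subtype (Rattus norvegicus) (on this read-out lower numbers stand for stronger inhibition and higher numbers for weaker inhibition), compound 1 gives 63 nM. Compound 2 `CC(C)(C)c1ccc(CN(Cc2cccc(CCC(=O)O)c2)S(=O)(=O)c2ccc(Cl)cc2)cc1` differs from it only by a 4-chlorophenyl group in that place. For compound 2 this assay reports only a limit, > 3200 nM, rather than a number. The step of an at least 50-fold higher number from compound 1 to compound 2 (1.70 log units; beyond the scatter) is therefore a large loss of inhibition, and its true size is known only as a bound, because compound 2 sits at the limit of > 3200 nM in this assay, at which 1 of the 2 values shown sits. Compound 3 `CC(C)(C)c1ccc(CN(Cc2cccc(CCC(=O)O)c2)S(=O)(=O)c2ccccn2)cc1` is built from compound 2 by one further exchange: pyridin-2-yl in place of 4-chlorophenyl on a sulfonyl sulfur. Going by the values given here, the only measured step that bears on this exchange is the one from compound 1 to compound 2, which replaced a heteroaromatic ring on the sulfonyl sulfur by a carbon-only ring and cost a great deal. Compound 3 reverses that kind of exchange, so a large gain is expected, of about an at least 21-fold lower number from compound 2 to compound 3 (1.32 log units; beyond the scatter). Compound 3 is estimated at 150 nM, with a likely range from 40 nM to 1500 nM.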

Compound 3, half-maximal inhibitory concentration: 52 nM
Estimate against measurement, compound 3: 2.9-fold (0.46 log units) above; the range from low to high includes it.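

Pyridin-2-yl in place of 4-chlorophenyl on the sulfonyl sulfur gives an at least 61-fold lower number from compound 2 to compound 3 (1.78 log units; beyond the scatter), so in this assay the large loss seen with compound 2 is undone by changing this one ring. The size of that recovery is known only as a bound, because compound 2 has a limit rather than a number: the limit of > 3200 nM in this assay, at which 1 of the 3 values shown sits. The step of a 1.2-fold lower number from compound 1 to compound 3 (0.08 log units; within the scatter) adds something that compound 1 and compound 2 alone could not show: two different rings that each contain a hetero atom cannot be told apart on this read-out, so the high inhibition does not belong to 1,3-thiazol-2-yl alone.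

On these data alone, what stays open is which part of the exchange matters, since 4-chlorophenyl differs from pyridin-2-yl both in its chlorine and in having a ring of carbon only. A plain phenyl group on the sulfonyl sulfur would separate these two differences, and pyridin-3-yl or pyridin-4-yl would test whether the place of the ring nitrogen counts.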